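Expected effect of a hydroxynaphthyl arm in compound 3

This account rests on a few compounds, and the source may have more. Where it says the series, first, only, none or still open, it means among the compounds named here.

Compound 1 `CCCCc1oc2ccc(/N=C/c3ccccc3)cc2c1C(=O)c1ccc(OC)cc1`: 34.2 ug/mL
Compound 2 `CCCCc1oc2ccc(/N=C/c3ccc(OCC)c(OC)c3)cc2c1C(=O)c1ccc(OC)cc1`: 14.8 ug/mL

In a functional assay, with a stated time of 30 min (on this read-out lower numbers stand for stronger inhibition and higher numbers for weaker inhibition), compound 1 gives 34.2 ug/mL and compound 2 gives 14.8 ug/mL, so compound 1 carries the higher of the two numbers. Compound 3 `CCCCc1oc2ccc(/N=C/c3ccccc3-c3cc4ccccc4cc3O)cc2c1C(=O)c1ccc(OC)cc1` is not yet measured. It differs from compound 1 in one place: 3-hydroxynaphthalen-2-yl in place of hydrogen on an aromatic carbon. Going by the values given here, the only measured step, a 2.3-fold lower number from compound 1 to compound 2 (0.36 log units; beyond the scatter), also changed what sits on the carbon with a double bond to nitrogen, though by smaller additions, so it bears on this change only loosely. A modest gain is therefore expected for compound 3, a 1.7-fold lower number from compound 1 to compound 3 (0.23 log units; within the scatter), with wide uncertainty. Compound 3 is estimated at 20 ug/mL, between 7 ug/mL and 50 ug/mL.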

Compound 3, half-maximal inhibitory concentration: 39.5 ug/mL
The estimate for compound 3 lay 2.0-fold (0.30 log units) below the measured number, and the stated range covers the measured number.
By their numbers in this assay, from the lowest: compound 2; then compounds 1 and 3 (each within the scatter of the next).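

In this assay the 3-hydroxynaphthalen-2-yl group, on an aromatic carbon ortho to a large group, gives a 1.2-fold higher number from compound 1 to compound 3 (0.06 log units; within the scatter). This position therefore accepts a large addition carrying two aromatic rings with neither a readable gain nor a readable loss, unlike the change on the same arm that gave a 2.3-fold lower number from compound 1 to compound 2 (0.36 log units; beyond the scatter). No measurement here explains this result.

On these data alone, whether a small amine or a carboxylic acid at this place would move the number stays open. So does whether the hydroxy group matters apart from the rings that carry it.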